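The source may hold more compounds than are shown below. What is called first, only, known or untested is meant among the compounds shown, and "the series" means these compounds.

Series measured in a functional assay on brain (Rattus norvegicus, strain Wistar) for inhibition; on this read-out lower numbers stand for stronger inhibition and higher numbers for weaker inhibition:

- Compound 1 `Cc1[nH]c(=O)n(C)c1-c1ccccc1` gives > 100000 nM, which is a limit of the assay and not a number.
- Compound 2 `CCCc1ccc(-c2c(C)[nH]c(=O)n2C)cc1` gives 21500 nM.
- Compound 3 `CCCCCCc1ccc(-c2c(C)[nH]c(=O)n2C)cc1` gives 9000 nM.

Compound 3 has the lowest of the two numeric values in this assay, and its nearest neighbour is compound 2, with a 2.4-fold lower number from compound 2 to compound 3 (0.38 log units; beyond the scatter). The steps starting at compound 1, an at least 4.6-fold lower number from compound 1 to compound 2 (0.66 log units; beyond the scatter) and an at least 11-fold lower number from compound 1 to compound 3 (1.04 log units; beyond the scatter), are bounds only, as they start from the limit of > 100000 nM in this assay, at which 1 of the 3 values shown sits.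

Compound 4 `CCCCCCCc1ccc(-c2c(C)[nH]c(=O)n2C)cc1` is next. The change is methyl in place of hydrogen on a saturated chain carbon, six bonds along the chain from an aromatic carbon.

For the measured compounds named here, the closest precedent is the propyl that enters at a saturated chain carbon between compound 2 and compound 3, a 2.4-fold lower number from compound 2 to compound 3 (0.38 log units; beyond the scatter). That single modest step is the only one measured on the chain itself. Methyl is a smaller addition than propyl, so a smaller change is expected, and the three values do not show whether the trend continues. The expected change is a 1.2-fold lower number from compound 3 to compound 4 (0.08 log units; within the scatter), a slightly lower number at most and probably no step beyond the scatter. For compound 4 the estimate is 7500 nM, with an expected range of 3500 nM to 16000 nM.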

Compound 4, half-maximal inhibitory concentration: 8400 nM
For compound 4 the middle estimate is 1.1-fold (0.05 log units) below the measured one; the measured number falls inside the stated range.
By their numbers in this assay, from the lowest: compounds 4 and 3 (each within the scatter of the next); then compound 2. At a limit, above all of these: compound 1.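

In this assay, methyl on a saturated chain carbon, six bonds along the chain from an aromatic carbon, gives a 1.1-fold lower number from compound 3 to compound 4 (0.03 log units; within the scatter), so the heptyl chain of compound 4 and the hexyl chain of compound 3 are not separated, and this position offers no further step beyond the scatter. Over the longer stretch of chain the change is a 2.6-fold lower number from compound 2 to compound 4 (0.41 log units; beyond the scatter), a modest step that stands beside the one already seen for the hexyl chain of compound 3, so among the numeric values both longer chains sit apart from the propyl chain of compound 2, while the last single carbon adds nothing that can be resolved. The remaining step, an at least 11-fold lower number from compound 1 to compound 4 (1.07 log units; beyond the scatter), is a bound only. It cannot be read as a size, as compound 1 stands at a limit and not a number: the limit of > 100000 nM in this assay, at which 1 of the 4 values shown sits.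

From the compounds shown here alone, whether the flat stretch holds for a longer chain such as octyl or decyl, or whether the numbers turn upward again, stays open. Also open, going by these compounds, is how this assay responds to an amine or a carboxylic acid at the end of the chain in place of the terminal methyl.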